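Methyl at the saturated ring carbon of compound 3

A few compounds are considered here, and "the series" means these few. Any claim that something is new, unique, unknown or untested is made for them only; others in the source may bear on it.

Three compounds of the shared core have been run in a functional assay on L1210 cells (Mus musculus) for antiproliferative activity, with a stated time of 48 h; on this read-out lower numbers stand for stronger inhibition and higher numbers for weaker inhibition. Compound 1 `CCOC(=O)Nc1cc2c(c(N)n1)N=C(c1ccccc1)C(c1ccccc1)O2` gives 0.88 uM. Compound 2 `CCOC(=O)Nc1cc2c(c(N)n1)N=C(c1ccc(Cl)cc1)CO2` gives > 3 uM, which is a limit of the assay and not a number. Compound 3 `CCOC(=O)Nc1cc2c(c(N)n1)N=C(c1ccccc1)CS2` gives 6.1 uM, the higher of the two numbers in this assay; compound 1 sits below it by a gap that is beyond the usual scatter. Among the compounds with values here, no pair among the measured compounds differs in one place only, so no step has been measured.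

Compound 4 `CCOC(=O)Nc1cc2c(c(N)n1)N=C(c1ccccc1)C(C)S2` is the next compound to be run in this assay. It differs from compound 3 in one place: methyl in place of hydrogen on a saturated ring carbon. Nothing measured here speaks to a change of this kind, so a step of no more than the scatter is expected, in either direction. The value of compound 4 in this assay is therefore estimated at 5 uM, within 2 uM to 12 uM, which corresponds to an expected step of a 1.2-fold lower number from compound 3 to compound 4 (0.09 log units; within the scatter).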

Compound 4, concentration for 50% inhibition: 1.6 uM
For compound 4 the middle estimate is 3.1-fold (0.49 log units) above the measured one; measured number below the stated range.
By their numbers in this assay, from the lowest: compounds 1 and 4 (each within the scatter of the next); then compound 3.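

In this assay, the first step measured within the series is a 3.8-fold lower number from compound 3 to compound 4 (0.58 log units; beyond the scatter), so the saturated ring carbon next to the ring sulfur is a position where a small change registers on this read-out. Methyl in place of hydrogen at this carbon moves the number beyond the scatter, in the direction of stronger inhibition, so this carbon tolerates the added group. This rests on one pair only, and no measured property accompanies it, so the step carries no explanation.

On these data alone, whether ethyl, a longer chain, hydroxymethyl or a carboxylic acid at this carbon would extend, hold or reverse the step remains open, as does whether methyl acts alike on other members. Compound 2 offers no number for such a comparison, only a limit: the limit of > 3 uM in this assay, at which 1 of the 4 values shown sits.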